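Swapping fluorophenyl for benzyl on the triazole of compound 3

The compounds below may be only part of what the source reports. "The series", "measured", "known", "first", "only" and "open" are said of these compounds alone.

Measured compounds:
- compound 1 `CCCCCc1ccc(C#Cc2c(-c3ccc(CCCCC)cc3)oc3nc(=O)n(Cc4cn(-c5ccccc5F)nn4)cc23)cc1`: 9000 nM
- compound 2 `O=c1nc2oc(CCCCl)c(C#CCCCCl)c2cn1Cc1cn(Cc2ccccc2)nn1`: 25400 nM
- compound 3 `O=c1nc2oc(CCCCl)cc2cn1Cc1cn(-c2ccc(F)cc2)nn1`: 6990 nM

All three compounds were tested in a functional assay on HeLa cells (Homo sapiens) for antiproliferative activity, read by MTT assay, with a stated time of 72 h; on this read-out lower numbers stand for stronger inhibition and higher numbers for weaker inhibition. Compound 3 gives the lowest number of the three, with 6990 nM. Its gap to compound 1, which gives 9000 nM, is within the scatter, so the two cannot be ranked against each other. The gap to compound 2, which gives 25400 nM, is beyond the scatter, so compound 3 does show stronger inhibition than compound 2.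

Compound 4 `O=c1nc2oc(CCCCl)cc2cn1Cc1cn(Cc2ccccc2)nn1` has not yet been measured. It keeps the shared core of compound 3 and changes one group: benzyl in place of 4-fluorophenyl on an aromatic nitrogen. Among the measured compounds shown here, no pair of measured compounds differs by exactly this change, so nothing measured tells directly what it does. Compound 2 also carries a benzyl on that ring nitrogen, but it differs from compound 3 in other places as well, so its higher value says little on its own. A step of small size, in either direction or none beyond the scatter, is expected in this assay. Compound 4 is therefore estimated at 9000 nM, with a range from 3500 nM to 25000 nM, which means an expected step of a 1.3-fold higher number from compound 3 to compound 4 (0.11 log units; within the scatter).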

Compound 4, half-maximal inhibitory concentration: 9580 nM
Estimate against measurement, compound 4: 1.1-fold (0.03 log units) below, and the stated range covers the measured number.
By their numbers in this assay, from the lowest: compounds 3, 1 and 4 (each within the scatter of the next); then compound 2.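

In this assay, among the compounds shown here, benzyl in place of 4-fluorophenyl on the aromatic nitrogen of the five-membered ring gives a 1.4-fold higher number from compound 3 to compound 4 (0.14 log units; within the scatter), the first direct reading of this change, and it shows that these two groups, each with one six-membered aromatic ring of carbon only, cannot be told apart here. With benzyl held fixed, hydrogen in place of 5-chloropent-1-yn-1-yl on an aromatic carbon gives a 2.7-fold lower number from compound 2 to compound 4 (0.42 log units; beyond the scatter), so in this pair the higher number of compound 2 goes with that chain and not with the benzyl it shares with compound 4. Nothing available explains either step.

From the compounds shown here alone, only benzyl and 4-fluorophenyl can be compared at this nitrogen on this core, so it remains open whether a different group there, such as a cyclohexyl or a 2-phenylethyl, would move the number beyond the scatter. Going by these compounds, it is also open whether the step seen on removing 5-chloropent-1-yn-1-yl would hold with 4-fluorophenyl on the nitrogen, and what a shorter chain or an amine on that aromatic carbon would do.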